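This account rests on a few compounds, and the source may have more. Where it says the series, first, only, none or still open, it means among the compounds named here.

Three compounds of this series have numbers in a functional assay on BJAB cells (Homo sapiens) for antiproliferative activity, with a stated time of 4 days; on this read-out lower numbers stand for an effect already at smaller amounts and higher numbers for an effect only at larger amounts of compound. Compound 1 `COC(=O)c1c(Cc2ccccc2[N+](=O)[O-])c(C)nn1-c1nc(-c2ccc(Cl)c(Cl)c2)cs1`, with an ester and a nitrobenzyl group on the shared core, gives 377000 nM. Compound 2 `Cc1nn(-c2nc(-c3ccc(Cl)c(Cl)c3)c(SC(C)C)s2)c(C(=O)O)c1-c1cccc(Cl)c1C`, which carries the carboxy group and the 3-chloro-2-methylphenyl group, gives 5100 nM. Compound 3 `Cc1nn(-c2nc(-c3ccc(Cl)c(Cl)c3)c(SC(C)C)s2)c(C(=O)O)c1-c1cc(C(F)(F)F)cc(C(F)(F)F)c1`, with the 3,5-bis(trifluoromethyl)phenyl group at the same position, gives 1800 nM. Compound 2 thus stands second highest of the three numbers: its nearest neighbour is compound 3, whose number is lower by a margin beyond the scatter, and its furthest is compound 1, far higher.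

Compound 4 `Cc1nn(-c2nc(-c3ccc(Cl)c(Cl)c3)c(SC(C)C)s2)c(C(=O)O)c1-c1cccc(F)c1` has not been measured in this assay. It differs from compound 2 in one place: 3-fluorophenyl in place of 3-chloro-2-methylphenyl on an aromatic carbon. Among the compounds with values here, no measured pair covers this exact change, so only the aryl variation between compound 2 and compound 3 gives any bearing, and it points to the aryl group mattering within a modest band. For compound 4 a small step toward a higher number is expected, a 1.6-fold higher number from compound 2 to compound 4 (0.20 log units; within the scatter), possibly not beyond the scatter. Compound 4 is estimated at 8000 nM, with a range from 2500 nM to 25000 nM.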

Compound 4, half-maximal effective concentration: 900 nM
Compound 4: the middle estimate sits 8.9-fold (0.95 log units) above what was measured, and the stated range ends above it.
By their numbers in this assay, from the lowest: compounds 4 and 3 (each within the scatter of the next); then compound 2; then compound 1.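

In this assay, the aryl group on this aromatic carbon of the shared core, next to the ring atom that bears a carboxy group, can move the number beyond the scatter: 3-fluorophenyl in place of 3-chloro-2-methylphenyl gives a 5.7-fold lower number from compound 2 to compound 4 (0.75 log units; beyond the scatter). Compound 3 at 1800 nM and compound 4 at 900 nM lie within the scatter of each other, although 3,5-bis(trifluoromethyl)phenyl and 3-fluorophenyl are quite different aryl groups. No measurement at hand explains the step.

The change from compound 2 to compound 4 removes the methyl and swaps chlorine for fluorine together, so the share of each stays unresolved. Also open, from the compounds shown here alone, is how an unsubstituted phenyl group, or an amine or methoxy group on this aryl ring, would read out.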